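The source may report more compounds than this note shows. Statements on the series, on what has been measured and on what is new or still open speak of the compounds shown alone.

Compound 3 `NCc1ccc(C(=O)Nc2ccncc2F)cc1-c1cccc(C(=O)O)c1` carries a hydrogen on the oxygen next to the carbonyl group, and in an assay on isolated protein for inhibition of Rho-associated protein kinase 2 (Homo sapiens), read by radiometric assay (a higher number here means a weaker inhibitor, a lower number a stronger inhibitor), compound 3 gives 55 nM, the highest number of the three compounds measured in this assay. Compound 1 `NCc1ccc(C(=O)Nc2ccncc2F)cc1-c1cccc(C(=O)OCC2CC2)c1`, with cyclopropylmethyl on that oxygen, gives 2.7 nM, and compound 2 `COC(=O)c1cccc(-c2cc(C(=O)Nc3ccncc3F)ccc2CN)c1`, with methyl there, gives 7.8 nM. Both steps to compound 3 point the same way: a 20-fold higher number from compound 1 to compound 3 (1.31 log units; beyond the scatter) and a 7.1-fold higher number from compound 2 to compound 3 (0.85 log units; beyond the scatter), so the bare hydrogen on that oxygen sits at the weak end of the series in this assay.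

Compound 4 `NCc1ccc(C(=O)Nc2ccncc2F)cc1-c1cccc(C(=O)OC2CCCOC2)c1` differs from compound 3 as follows: oxan-3-yl in place of hydrogen on an oxygen next to a carbonyl group. The relevant precedents are the steps from compound 1 and compound 2 to compound 3, which run in the opposite direction to the present change, so the change from compound 3 to compound 4 is expected to lower the number in this assay. The size expected for compound 4 is taken from those two steps, with the oxan-3-yl group judged to sit between methyl and cyclopropylmethyl in its effect; the step expected is an 11-fold lower number from compound 3 to compound 4 (1.04 log units; beyond the scatter). For compound 4 the estimate in this assay is 5 nM, with a range of 2 nM to 15 nM.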

Compound 4, half-maximal inhibitory concentration: 8.7 nM
Estimate against measurement, compound 4: 1.7-fold (0.24 log units) below; measured number inside the range.
By their numbers in this assay, from the lowest: compound 1; then compounds 2 and 4 (each within the scatter of the next); then compound 3.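

In this assay, a third group on the oxygen next to a carbonyl group again beats the bare hydrogen, with oxan-3-yl in place of hydrogen giving a 6.3-fold lower number from compound 3 to compound 4 (0.80 log units; beyond the scatter), so compounds 1, 2 and 4 all stand apart from compound 3 at this position. Oxan-3-yl in place of methyl gives a 1.1-fold higher number from compound 2 to compound 4 (0.05 log units; within the scatter), so these two groups cannot be told apart here. Oxan-3-yl in place of cyclopropylmethyl gives a 3.2-fold higher number from compound 1 to compound 4 (0.51 log units; beyond the scatter), which shows that having a ring on this oxygen does not by itself match compound 1. No measurement is available that bears on why these groups rank as they do.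

From the compounds shown here alone, whether the ring oxygen of oxan-3-yl matters remains open, and a cyclohexyl or oxan-4-yl group on the same oxygen would address that. Also open, going by these compounds, is whether the gain over hydrogen survives with a longer chain such as 2-methoxyethyl on this oxygen, or with an amide nitrogen in place of the oxygen itself.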